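Dropping the acetoxy group from a brominated lactone

The source may report more compounds than this note shows. Statements on the series, on what has been measured and on what is new or still open speak of the compounds shown alone.

Measured compounds:
- Compound 1, `CCC[C@@H](OC(C)=O)C1=C(Br)C(=C(Br)Br)OC1=O`: 3.5 ug/mL
- Compound 2, `CCC[C@@H](OC(C)=O)C1=C(Br)[C@@](OC)(C(Br)Br)OC1=O`: 6.2 ug/mL
- Compound 3, `CCCCC1=C(Br)C(OC)(C(Br)Br)OC1=O`: 8 ug/mL

All three compounds share a brominated lactone core and a short alkyl chain, and all were tested in a functional assay on KB cells (Homo sapiens) for cytotoxicity; a higher number here means that more compound is needed for the effect, a lower number that less compound is needed. Compound 1 gives the lowest number of the three. Compound 2 sits closest to it, and the gap between them is within the usual scatter, so the two cannot be told apart. Compound 3 is furthest away, with a gap that lies beyond the scatter, so compound 3 needs more compound than compound 1 for the same effect.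

Compound 4, `CCCCC1=C(Br)C(=C(Br)Br)OC1=O`, has not yet been tested. It differs from compound 1 in one place: hydrogen in place of acetoxy on a saturated chain carbon bound to a double-bonded ring carbon and a saturated chain carbon. Compound 2 and compound 3 carry the same side-chain difference, acetoxy against hydrogen, on a different core, and their two values lie within the scatter of each other.

Because compound 2 shows 6.2 ug/mL against compound 3 with 8 ug/mL, the step of a 1.4-fold higher number from compound 1 to compound 4 (0.15 log units; within the scatter) is expected to be small and toward a slightly higher number, not clearly beyond the scatter. Compound 4 is therefore estimated to give 5 ug/mL, with a likely range from 2.5 ug/mL to 10 ug/mL.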

Compound 4, concentration for half-maximal effect: > 20 ug/mL
Compound 4 was reported as a limit; the forecaster's own chance of this, stated with the estimate: 5%; middle value at least 4.0-fold (0.60 log units) away from the limit.
By their numbers in this assay, from the lowest: compounds 1, 2 and 3 (each within the scatter of the next, the first and the last beyond it). At a limit, above all of these: compound 4.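

Compound 4 gives no number in this assay, only a limit: the limit of > 20 ug/mL in this assay, at which 1 of the 4 values shown sits.

On the core of compound 1, hydrogen in place of acetoxy on this saturated chain carbon gives an at least 5.7-fold higher number from compound 1 to compound 4 (0.75 log units; beyond the scatter), so this is a change that the read-out clearly registers, and the acetoxy group counts for the cytotoxicity seen with compound 1. Compound 2 and compound 3 carry the same side-chain difference on a different core, yet their numbers lie within the scatter of each other, so the outcome of this change depends on the core it is made on, something those two compounds alone could not reveal.

The compounds shown leave open whether a hydroxyl group, a methoxy group or a larger ester such as benzoyloxy on this carbon would keep the number near that of compound 1 or lose it as hydrogen does. Also open, from the compounds shown here alone, are how the mirror-image arrangement at this carbon would behave and whether a longer chain would alter the picture on either core.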